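This account rests on a few compounds, and the source may have more. Where it says the series, first, only, none or still open, it means among the compounds named here.

Three compounds were examined in a functional assay on the whole organism (strain Swiss) with Mus musculus as the target, in the maximal electroshock model, with a stated time of 0.25 h; a lower number here means that less compound is needed, a higher number that more compound is needed for the effect. Compound 1, `CCC(C(=O)N1CCN(c2cccc(C(F)(F)F)c2)CC1)N1C(=O)CC(C)C1=O`, gives 75.1 mg/kg in this assay. Compound 2, `CCC(C(=O)N1CCN(c2cccc(Cl)c2)CC1)N1C(=O)CC(C)C1=O`, gives 117 mg/kg in this assay. Compound 3, `CC(C(=O)N1CCN(c2cccc(Cl)c2)CC1)N1C(=O)CC(C)(C)C1=O`, gives 120 mg/kg in this assay, and its number sits close to that of compound 2, the two lying within the scatter of each other; compounds 2 and 3 have the same atoms joined differently, and the difference between their two cores is not broken down here.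

The one change that is made twice among these compounds is trifluoromethyl in place of chloro on an aromatic carbon, and it produced a 1.6-fold lower number from compound 2 to compound 1 (0.19 log units; within the scatter). Compound 4, `CC(C(=O)N1CCN(c2cccc(C(F)(F)F)c2)CC1)N1C(=O)CC(C)(C)C1=O`, carries the same change relative to compound 3, namely (trifluoromethyl in place of chloro on an aromatic carbon); the place of the change is the same in both pairs, so it is the same change applied to the core of compound 3 rather than to the core of compound 2.

Because the step of a 1.6-fold lower number from compound 2 to compound 1 (0.19 log units; within the scatter) stayed within the scatter, the step from compound 3 to compound 4 is expected to be of a like size, about a 1.5-fold lower number from compound 3 to compound 4 (0.18 log units; within the scatter), resting on one measured pair only. Compound 4 is therefore estimated to give about 80 mg/kg in this assay, with a range from 45 mg/kg to 150 mg/kg, starting from the value of compound 3, 120 mg/kg.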

Compound 4, dose for half-maximal effect: 114 mg/kg
Compound 4: middle estimate off by 1.4-fold (0.15 log units), on the low side; measured number inside the range.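

In this assay, trifluoromethyl in place of chloro on an aromatic carbon gave a 1.1-fold lower number from compound 3 to compound 4 (0.02 log units; within the scatter). Set beside the earlier step, the change shows no difference between the two cores that can be told from the scatter: the same change on two cores in this assay, a 1.6-fold lower number (0.19 log units; within the scatter) from compound 2 to compound 1 and a 1.1-fold lower number (0.02 log units; within the scatter) from compound 3 to compound 4, 1.5-fold (0.17 log units) apart, within the scatter of two such steps. This shows that the two cores agree as far as these measurements can tell, but since both steps lie within the scatter, neither pair shows that the change has a real effect in this assay, and two pairs cannot show that the same result would hold on a further core.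

Going by these compounds, only chloro and trifluoromethyl appear at this place on the aromatic ring, so it remains open what a nitrile, a methoxy group or an amine would give there in this assay. The comparison also leaves open whether a larger step from either of these groups would carry over between the two cores in the same way, as steps this small offer little to compare.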